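Removing the tert-butyl from compound 2

A few compounds are considered here, and "the series" means these few. Any claim that something is new, unique, unknown or untested is made for them only; others in the source may bear on it.

Measured so far in a functional assay on MCF7 cells (Homo sapiens) for inhibition, read by MTT assay, with a stated time of 72 h; on this read-out lower numbers stand for stronger inhibition and higher numbers for weaker inhibition
- Compound 1 `Brc1ccc(-c2nnc(SCCCN3CCN(c4nc5ccccc5s4)CC3)o2)cc1` gives 96300 nM
- Compound 2 `CC(C)(C)Oc1ccc(-c2nnc(SCCCN3CCN(c4nc5ccccc5s4)CC3)o2)cc1` gives 89300 nM

Compound 2 and compound 1 lie within the scatter of each other, so neither ranks ahead on these numbers. Compound 3 `Oc1ccc(-c2nnc(SCCCN3CCN(c4nc5ccccc5s4)CC3)o2)cc1` follows from compound 2 through hydrogen in place of tert-butyl on an oxygen on an aromatic ring and carries hydrogen in place of tert-butyl on an oxygen on an aromatic ring. Among the measured compounds shown here, no measured step covers this exact change. The nearest guide is the swap of bromo for tert-butoxy on an aromatic carbon, which gave a 1.1-fold lower number from compound 1 to compound 2 (0.03 log units; within the scatter) and so offers no sign of a large response to a change in this group. The expected change in this assay is a 1.1-fold lower number from compound 2 to compound 3 (0.05 log units; within the scatter) and no shift beyond the scatter is expected in either direction. Compound 3 is estimated at 80000 nM with an expected range from 40000 nM to 160000 nM on this read-out.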

Compound 3, half-maximal inhibitory concentration: 81900 nM
Beside the measured number, compound 3's estimate is 1.0-fold (0.01 log units) below it; the measured number falls inside the stated range.
By their numbers in this assay, from the lowest: compounds 3, 2 and 1 (each within the scatter of the next).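

In this assay, taking off the tert-butyl to leave a free hydroxy gives a 1.1-fold lower number from compound 2 to compound 3 (0.04 log units; within the scatter), so this place on the aromatic ring tolerates the loss of the whole tert-butyl with no shift that can be told from the scatter. Hydroxy in place of bromo gives a 1.2-fold lower number from compound 1 to compound 3 (0.07 log units; within the scatter), which shows that bromo, tert-butoxy and hydroxy all read alike here, whereas the earlier pair had compared only the first two of these groups. Nothing available explains this flat response.

From the compounds shown here alone, whether any group at this place can move the number beyond the scatter stays open, for instance an amine or a carboxylic acid. Going by these compounds, it is also open whether a change elsewhere in the shared core, such as a longer chain, would do so.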